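Chain shortening by ethyl on two related cores

A few compounds are considered here, and "the series" means these few. Any claim that something is new, unique, unknown or untested is made for them only; others in the source may bear on it.

Compound 1 `CCCCCCCCCCN1NN=C(NC(=O)Nc2c(C(C)C)cccc2C(C)C)N1` and compound 2 `CCCCCCCCCCCCN1NN=C(NC(=O)Nc2c(C(C)C)cccc2C(C)C)N1` share one core and differ only in chain length. In an assay on microsomes from intestine for inhibition of acyl-CoA:cholesterol acyltransferase (Oryctolagus cuniculus) (on this read-out higher numbers stand for weaker inhibition and lower numbers for stronger inhibition), compound 1 gives 14 nM and compound 2 gives 14 nM. The step of no change at the digits printed from compound 2 to compound 1 (within the scatter) corresponds to hydrogen in place of ethyl on a saturated chain carbon, ten or more bonds along the chain from an amine nitrogen in a ring.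

Compound 3 `CCCCCCCCCCCc1nnc(NC(=O)Nc2c(C(C)C)cccc2C(C)C)s1` carries a different core; the difference between the two cores is not broken down here. In this assay compound 3 gives 390 nM, the highest number of the three, and its gap to both compound 1 and compound 2 lies beyond the scatter.

Compound 4 `CCCCCCCCCc1nnc(NC(=O)Nc2c(C(C)C)cccc2C(C)C)s1` is derived from compound 3 by hydrogen in place of ethyl on a saturated chain carbon, nine bonds along the chain from an aromatic carbon. This is the same kind of change as that from compound 2 to compound 1, but not the same: the place of the change on the chain is described from a different part of the molecule on each core, as the two difference descriptions show.

The step of no change at the digits printed from compound 3 to compound 4 (within the scatter) is expected to be small, because no change at the digits printed from compound 2 to compound 1 (within the scatter) was within the scatter on the other core. Compound 4 is therefore estimated at 390 nM, with a range from 150 nM to 1000 nM.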

Compound 4, half-maximal inhibitory concentration: 150 nM
Estimate against measurement, compound 4: 2.6-fold (0.41 log units) above, within the range that was stated.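

In this assay, hydrogen in place of ethyl on the core of compound 3 gives a 2.6-fold lower number from compound 3 to compound 4 (0.41 log units; beyond the scatter), a modest step on its own. Set beside the same change on the core of compound 1, this step does not stand apart from the earlier one: the same change on two cores in this assay, no change at the digits printed (within the scatter) from compound 2 to compound 1 and a 2.6-fold lower number (0.41 log units; beyond the scatter) from compound 3 to compound 4, 2.6-fold (0.41 log units) apart, within the scatter of two such steps The change can therefore be carried from one core to the other in this series without a measurable difference in its size, but a single pair on each core shows neither that the two steps are truly equal nor that the core has no influence on them.

Still open is how a much shorter chain, such as hexyl, or a longer chain than any shown here would behave on each core, and whether the two cores would then continue to track each other. Also open, as far as these compounds go, is whether the same agreement would hold for a chain ending in an amine or a carboxylic acid.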